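Swapping the Sulfonyl Group: From Compound 1 to Compound 4

The compounds below may be only part of what the source reports. "The series", "measured", "known", "first", "only" and "open" are said of these compounds alone.

Compound 1 `O=S(=O)(Nc1ccc(-c2nc3ccccc3o2)cc1)c1ccc(Cl)s1`: 31000 nM
Compound 2 `O=S(=O)(Nc1ccc2oc(-c3ccccc3)nc2c1)c1cccc(O)c1`: 76000 nM
Compound 3 `Cc1ccc(S(=O)(=O)Nc2ccc3oc(-c4ccccc4)nc3c2)cc1`: limit only, > 100000 nM

In an assay on cells for inhibition of HSP60/HSP10 (Homo sapiens), with a stated time of 60 min (a lower number here means a stronger inhibitor, a higher number a weaker inhibitor), compound 1 gives 31000 nM, the lowest of the two numbers shown, while compound 2 gives 76000 nM. For compound 3 the assay reports only a limit, > 100000 nM, which is the limit of > 100000 nM in this assay, at which 1 of the 3 values shown sits.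

Compound 4 `Cc1ccc(S(=O)(=O)Nc2ccc(-c3nc4ccccc4o3)cc2)cc1` has not yet been measured. It differs from compound 1 in one place: 4-methylphenyl in place of 5-chlorothiophen-2-yl on a sulfonyl sulfur. Going by the values given here, the only measured step that bears on this is an at least 1.3-fold higher number from compound 2 to compound 3 (0.11 log units; that floor lies within the scatter), where the same 4-methylphenyl group entered on a sulfonyl sulfur and the number ran to the assay limit. A higher number, meaning weaker inhibition, is therefore expected for compound 4 in this assay, though with a limit possible. The estimate for compound 4 is 70000 nM, within 30000 nM to 200000 nM. This corresponds to an expected 2.3-fold higher number from compound 1 to compound 4 (0.35 log units; beyond the scatter).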

Compound 4, half-maximal inhibitory concentration: > 100000 nM
Compound 4 was reported as a limit (the forecaster's own chance of this, stated with the estimate: 35%); at least 1.4-fold (0.15 log units) between middle value and limit.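

In this assay, 4-methylphenyl on the sulfonyl sulfur now gives a step that clears the scatter: an at least 3.2-fold higher number from compound 1 to compound 4 (0.50 log units; beyond the scatter). The earlier step with this group, on a different core, had a floor still within the scatter, so only here does 5-chlorothiophen-2-yl clearly outperform 4-methylphenyl at this position. This step is only a floor, as compound 4 is reported as a limit: the limit of > 100000 nM in this assay, at which 2 of the 4 values shown sit.

On these data alone, whether the chlorine or the five-membered ring carries the difference stays open. So does the result for a thiophen-2-yl group without chlorine, or for an aminophenyl group, on this sulfonyl sulfur.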